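The source may report more compounds than this note shows. Statements on the series, on what has been measured and on what is new or still open speak of the compounds shown alone.

In a functional assay on HCT-116 cells (Homo sapiens) for antiproliferative activity, read by MTT assay, with a stated time of 48 h (on this read-out lower numbers stand for stronger inhibition and higher numbers for weaker inhibition), compound 1 (`COc1cc(N(Cc2ccc(C)cc2)C(=O)CSc2nc3ccccc3s2)cc(OC)c1OC`) reads > 80000 nM as a limit, not a number. Among the compounds with values here, compound 2 (`COc1ccc(CN(C(=O)CSc2nc3ccccc3s2)c2cc(OC)c(OC)c(OC)c2)cc1OC`) gives 33900 nM and is the only compound so far with a true number. Compound 3 (`COc1cc(N(Cc2ccc(Cl)cc2)C(=O)CSc2nc3ccccc3s2)cc(OC)c1OC`) departs from compound 2 on a saturated chain carbon bound to an amide-type nitrogen (4-chlorophenyl in place of 3,4-dimethoxyphenyl on a saturated chain carbon bound to an amide-type nitrogen). Within the data shown here, the one measured step at this place is an at least 2.3-fold lower number from compound 1 to compound 2 (0.37 log units; beyond the scatter) and it is the only guide. Without 3,4-dimethoxyphenyl, a modest step toward weaker inhibition is expected in this assay again. The expected step is a 1.8-fold higher number from compound 2 to compound 3 (0.25 log units; within the scatter) in size. For compound 3 the estimated value is 60000 nM (expected range 25000 nM to 110000 nM).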

Compound 3, half-maximal inhibitory concentration: 603000 nM
Compound 3: the middle estimate sits 10-fold (1.00 log units) below what was measured; measured number outside the range, above it.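

In this assay, this place, a saturated chain carbon bound to an amide-type nitrogen, now has a step with true numbers at both ends: an 18-fold higher number from compound 2 to compound 3 (1.25 log units; beyond the scatter). The change from 3,4-dimethoxybenzyl to 4-chlorobenzyl therefore carries a large loss, whose size the earlier step could only bound. The change of methyl to chloro cannot be read, because compound 1 carries a limit and not a number: the limit of > 80000 nM in this assay, at which 1 of the 3 values shown sits.

Going by these compounds, how a single methoxy group, an amine or a carboxylic acid on this phenyl ring would read stays open.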